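Swapping oxolan-3-yl for dimethylamino on compound 2

This account rests on a few compounds, and the source may have more. Where it says the series, first, only, none or still open, it means among the compounds named here.

Of the compounds shown here, three have been tested so far in an ADME assay on microsomes from liver (Rattus norvegicus) for metabolic stability, with a stated time of 60 min, tested at 1 uM; on this read-out lower numbers stand for a less stable compound and higher numbers for a more stable compound. Compound 1 `COc1cc(-c2cnn3cc(OC)c(C(C)C)nc23)ccn1` gives 14%, compound 2 `COc1cc(-c2cnn3cc(OC)c(C4CCOC4)nc23)ccn1` gives 34%, and compound 3 `Cn1cc(-c2nc3c(-c4ccnc(OC5CC5)c4)cnn3cc2OCCCC(C)(C)O)cn1` gives 64%. Compound 2 therefore holds the middle place of the three, with compound 1 clearly lower and compound 3 clearly higher.

Compound 4 `COc1cc(-c2cnn3cc(OC)c(N(C)C)nc23)ccn1` keeps the rest of compound 2 and changes one group: dimethylamino in place of oxolan-3-yl on an aromatic carbon. Among the compounds with values here, only one measured step concerns this same place: oxolan-3-yl in place of isopropyl gave a number 20 percentage points higher from compound 1 to compound 2 (beyond the scatter). Compound 3 differs from compound 2 in more than one place, so it offers no clean comparison. Within the data shown here, no tested compound carries dimethylamino, which means this single step can only suggest a likely scale. Dimethylamino has no ring, and neither does the isopropyl of compound 1, which gives 14%, so a modest fall seems more likely than a rise. The expected step is a number 12 percentage points lower from compound 2 to compound 4 (beyond the scatter). In this assay, the estimated value for compound 4 is 22%, with an expected range of 6% to 45%.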

Compound 4, percent of the compound remaining: 3%
Compound 4: middle estimate off by 19 percentage points, on the high side; measured number outside the range, below it.
By their numbers in this assay, from the lowest: compound 4; then compound 1; then compound 2; then compound 3.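

In this assay, this position on an aromatic carbon, next to the ring nitrogen, now has three groups to compare, and the change to dimethylamino gives a large fall: a number 31 percentage points lower from compound 2 to compound 4 (beyond the scatter), in the opposite direction to the earlier rise from isopropyl to oxolan-3-yl. The two groups without a ring also do not read alike, since a number 11 percentage points lower from compound 1 to compound 4 (beyond the scatter), so the absence of a ring is not enough on its own to set the number at this place, and dimethylamino gives the lowest number of the three groups. Nothing available here explains why these three groups fall in this order.

Within the data shown here, with only one ring and one amine tested at this place, the compounds leave open whether the low number goes with the amine nitrogen on the aromatic carbon or with the open, ringless shape of dimethylamino. A pyrrolidine or a morpholine on the same core would bring the amine nitrogen and a ring together in one group and so help separate these two readings.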